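Swapping the Amine Ring on a Vanilloid Receptor Antagonist

A few compounds are considered here, and "the series" means these few. Any claim that something is new, unique, unknown or untested is made for them only; others in the source may bear on it.

Of the compounds shown here, three sharing one core have been measured in an assay on CHO cells for antagonist activity at transient receptor potential cation channel subfamily V member 1 (Homo sapiens), read by FLIPR; a higher number here means a weaker inhibitor, a lower number a stronger inhibitor. Compound 1 `CCCN(CCC)c1cc(C(F)(F)F)ccc1CNC(=O)C(C)c1ccc(NS(C)(=O)=O)c(F)c1` gives 0.3 nM. Compound 2 `CC(C(=O)NCc1ccc(C(F)(F)F)cc1N1CCCCCC1)c1ccc(NS(C)(=O)=O)c(F)c1` gives 1.6 nM, and compound 3 `CC(C(=O)NCc1ccc(C(F)(F)F)cc1N1CCC(C(F)(F)F)CC1)c1ccc(NS(C)(=O)=O)c(F)c1` gives 0.4 nM. Compound 3 stands second highest of the three numbers: its number is close to that of compound 1, the difference being a 1.3-fold higher number from compound 1 to compound 3 (0.12 log units; within the scatter), whereas the step of a 4.0-fold lower number from compound 2 to compound 3 (0.60 log units; beyond the scatter) lies beyond the scatter. Compound 4 `CC(C(=O)NCc1ccc(C(F)(F)F)cc1N1CCN(C2CCCCC2)CC1)c1ccc(NS(C)(=O)=O)c(F)c1` has not yet been measured. It differs from compound 3 in one place: 4-cyclohexylpiperazin-1-yl in place of 4-(trifluoromethyl)piperidin-1-yl on an aromatic carbon. Two measured steps change the same group on the same aromatic carbon. The step of a 5.3-fold higher number from compound 1 to compound 2 (0.73 log units; beyond the scatter) shows that one ring amine in place of the open-chain amine can weaken inhibition, while a 1.3-fold higher number from compound 1 to compound 3 (0.12 log units; within the scatter) shows that another ring amine leaves the number essentially unchanged. Among the measured compounds shown here, the entering group of compound 4, with its two rings, has no measured counterpart, so the direction rests on analogy alone. A modest weakening is expected, with wide uncertainty, and the step of a 5.0-fold higher number from compound 3 to compound 4 (0.70 log units; beyond the scatter) is the estimate for this change. Compound 4 is thus expected to give about 2 nM in this assay, within the range 0.4 nM to 10 nM.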

Compound 4, inhibition constant: 13.8 nM
Beside the measured number, compound 4's estimate is 6.9-fold (0.84 log units) below it, outside the stated range (above it).
By their numbers in this assay, from the lowest: compounds 1 and 3 (each within the scatter of the next); then compound 2; then compound 4.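

Among the compounds shown here, the 4-cyclohexylpiperazin-1-yl group shows that this aromatic carbon is far less forgiving than the earlier compounds suggested: in this assay there is a 35-fold higher number from compound 3 to compound 4 (1.54 log units; beyond the scatter), and measured against the open-chain dipropylamino group there is a 46-fold higher number from compound 1 to compound 4 (1.66 log units; beyond the scatter). Even against azepan-1-yl, the earlier ring amine that had already weakened inhibition, there is an 8.6-fold higher number from compound 2 to compound 4 (0.94 log units; beyond the scatter), which leaves compound 4 the weakest inhibitor of the four. Ring amines at this position therefore do not behave as one family, since the choice of ring amine can separate compounds by much more than the earlier steps revealed.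

Nothing measured here explains why the number rises so far. The second ring nitrogen and the added cyclohexyl ring enter together, so their contributions cannot be told apart from these compounds, whereas 4-cyclohexylpiperidin-1-yl, which keeps the cyclohexyl ring without the second ring nitrogen, and 4-methylpiperazin-1-yl, which keeps that nitrogen with only a methyl group in place of the cyclohexyl ring, would pull the two apart.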